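The source may hold more compounds than are shown below. What is called first, only, known or untested is meant among the compounds shown, and "the series" means these compounds.

Measured compounds, values in a functional assay on SW480 cells (Homo sapiens) for antiproliferative activity, read by MTT assay, with a stated time of 72 h; a higher number here means a weaker inhibitor, a lower number a stronger inhibitor:

compound 1, `O=c1cc(CSC(=S)N2CCCC2)oc2ccccc12` — 23400 nM
compound 2, `O=c1cc(CSC(=S)N2CCCCC2)oc2ccccc12` — 13700 nM
compound 3, `O=c1c(CSC(=S)N2CCCCC2)coc2cc(Cl)ccc12` — 790 nM

Compound 3 gives the lowest number of the three and is the strongest inhibitor of the measured set, its separation from compound 2 and from compound 1 lying beyond the usual scatter. Compound 2 and compound 3 share the thiocarbonyl-bound piperidin-1-yl, yet their cores differ in more than one place; the difference between the two cores is not broken down here, so the gap between them is reported only as the two values show it.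

For the measured compounds named here, the one change that is measured in isolation is pyrrolidin-1-yl in place of piperidin-1-yl on a thiocarbonyl carbon. It gave a 1.7-fold higher number from compound 2 to compound 1 (0.23 log units; within the scatter), a step that does not rise above the scatter.

Compound 4, `O=c1c(CSC(=S)N2CCCC2)coc2cc(Cl)ccc12`, awaits measurement in this assay. It arises from compound 3 by pyrrolidin-1-yl in place of piperidin-1-yl on a thiocarbonyl carbon, the same change as the measured one, at the same place. The step is expected to be a 1.5-fold higher number from compound 3 to compound 4 (0.18 log units; within the scatter), modelled on the earlier step because compound 1 sits at 23400 nM against compound 2 at 13700 nM. Compound 4 is therefore estimated at 1200 nM, with an expected range from 500 nM to 3000 nM.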

Compound 4, half-maximal inhibitory concentration: 7800 nM
Beside the measured number, compound 4's estimate is 6.5-fold (0.81 log units) below it, outside the stated range (above it).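

In this assay, pyrrolidin-1-yl in place of piperidin-1-yl on a thiocarbonyl carbon gives a 9.9-fold higher number from compound 3 to compound 4 (0.99 log units; beyond the scatter), and this step differs from the earlier one on the other core: the same change on two cores in this assay, a 1.7-fold higher number (0.23 log units; within the scatter) from compound 2 to compound 1 and a 9.9-fold higher number (0.99 log units; beyond the scatter) from compound 3 to compound 4, 5.8-fold (0.76 log units) apart, beyond the scatter of two such steps

The size of this change therefore does not carry over from the core of compound 2 to the core of compound 3, and only on the core of compound 3 does the step rise above the scatter. The two pairs do not show which of the several differences between the cores goes with this gap, and two cores give no rule for any other core in the series.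

Still open, going by these compounds, is how a core differing from that of compound 3 in one place only would respond to the same change, which would begin to separate those differences. Also open, on these data alone, is whether another amine on the thiocarbonyl carbon, such as morpholine or the open-chain diethylamine, would follow piperidin-1-yl or pyrrolidin-1-yl on either core.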